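The source may report more compounds than this note shows. Statements on the series, on what has been measured and on what is new or still open speak of the compounds shown alone.

Measured so far:
- compound 1, `CNC(=O)c1cc(C(=O)NC2CC2)cn(Cc2ccc3nc[nH]c3c2)c1=O`: 1.2
- compound 2, `CNC(=O)c1cc(C(N)=O)cn(Cc2ccccc2)c1=O`: 2

Both compounds were measured in a physicochemical assay for lipophilicity, at pH 7.4; on this read-out lower numbers stand for lower lipophilicity and higher numbers for higher lipophilicity. Compound 1 gives 1.2, the lowest of the two numbers, and compound 2 gives 2, a number higher by more than the usual scatter. These two compounds differ in more than one place, so their gap cannot be tied to a single structural change.

The compound not yet measured is compound 3, `CNC(=O)c1cc(C(=O)NC2CC2)cn(Cc2cccc([C@@H](C)O)c2)c1=O`. It differs from compound 1 in one place: 3-(1-hydroxyethyl)phenyl in place of 1H-benzimidazol-6-yl on a saturated chain carbon bound to an aromatic nitrogen. The rest of the molecule is unchanged.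

Going by the values given here, no single-point step between measured compounds exists to guide this change, so the expectation rests on the two values shown. Compound 2 sits at 2 in this assay, and compound 3 is expected to move toward that number rather than away from it. For compound 3 the expected step from compound 1 is a number 0.60 log units higher from compound 1 to compound 3 (beyond the scatter), an increase beyond the scatter. Compound 3 is therefore estimated at 1.8 in this assay, with a likely range from 1.3 to 2.3.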

Compound 3, distribution coefficient: 2.2
Compound 3: the middle estimate sits 0.40 log units below what was measured; the measured number falls inside the stated range.
By their numbers in this assay, from the lowest: compound 1; then compounds 2 and 3 (each within the scatter of the next).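

Going by these compounds alone, on a saturated chain carbon bound to an aromatic nitrogen, putting 3-(1-hydroxyethyl)phenyl in place of 1H-benzimidazol-6-yl gives, in this assay, a number 1.00 log units higher from compound 1 to compound 3 (beyond the scatter) and provides the first step here that can be tied to a single structural change. The two groups match in their counts of heavy atoms, hydrogen-bond donors and acceptors, and in having no net charge, so this read-out can shift at this position even when those counts stay the same. What does differ is that the entering group has a single aromatic ring, carries oxygen rather than nitrogen and has a defined stereocentre, but nothing available here connects any of these features to the step.

One step cannot separate the effect of exchanging the ring system from that of adding the 1-hydroxyethyl group, and the role of the stereocentre also remains unresolved. How this assay would respond to an aminomethyl group or a carboxylic acid in place of that 1-hydroxyethyl group also remains an open question.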